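The compounds below may be only part of what the source reports. "The series", "measured", "known", "first", "only" and "open" are said of these compounds alone.

Working notes on the series. Compound 1 `CN1CCN(c2ccc(NCc3ccccc3O)cc2)CC1` is recorded in a functional assay on Jurkat cells (Homo sapiens) for activation, with a stated time of 24 h (on this read-out higher numbers stand for an effect only at larger amounts of compound and lower numbers for an effect already at smaller amounts), as "not active" (no number reported), with no number given. Compound 2 `Oc1ccccc1CNc1ccc(-c2ccccc2)cc1` gives 1820 nM in this assay, and compound 3 `Oc1ccccc1CNc1ccc(-c2cccc(F)c2)cc1` gives 2020 nM in this assay. Within the data shown here, these two values fall within the scatter of each other, so compound 3 stands level with compound 2 on the numbers so far, and compound 1 offers no number to compare against. Among the measured compounds shown here, the single measured step, a 1.1-fold higher number from compound 2 to compound 3 (0.05 log units; within the scatter), concerns the 3-fluorophenyl group that is about to be exchanged.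

Compound 4 `Cc1ccccc1-c1ccc(NCc2ccccc2O)cc1` differs from compound 3 by 2-methylphenyl in place of 3-fluorophenyl on an aromatic carbon. Only a 1.1-fold higher number from compound 2 to compound 3 (0.05 log units; within the scatter) bears on this change, since it altered the same 3-fluorophenyl group, and that step stayed within the scatter. For the measured compounds named here, no measured step tests a methyl group anywhere, so the change rests on one point of comparison. The step expected in this assay is therefore small, in either direction or none beyond the scatter, namely a 1.1-fold higher number from compound 3 to compound 4 (0.04 log units; within the scatter). Compound 4 is estimated at 2200 nM in this assay, with a range from 900 nM to 6000 nM.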

Compound 4, half-maximal effective concentration: 5220 nM
For compound 4 the middle estimate is 2.4-fold (0.38 log units) below the measured one; the measured number falls inside the stated range.
By their numbers in this assay, from the lowest: compounds 2 and 3 (each within the scatter of the next); then compound 4.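

In this assay the aryl group on this aromatic carbon, para to a group of 9 heavy atoms, proves open to a measurable change: the exchange of 3-fluorophenyl for 2-methylphenyl gives a 2.6-fold higher number from compound 3 to compound 4 (0.41 log units; beyond the scatter) and the methyl in place of hydrogen gives a 2.9-fold higher number from compound 2 to compound 4 (0.46 log units; beyond the scatter) where the fluoro step had stayed within the scatter. Both steps are modest and point the same way, towards an effect only at larger amounts of compound, so among the aryl groups with a number, 2-methylphenyl alone separates from the others. Nothing measured on the properties of these groups bears on the result, so the gap between the methyl and fluoro compounds stays unexplained here.

The step from 3-fluorophenyl to 2-methylphenyl alters both the substituent and its place on the ring, and the compounds shown do not separate these two changes. Going by these compounds, how a methoxy group, an amine or a carboxylic acid on the same ring would read out remains open, as does any number for compound 1, which offers no value to set against the others.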